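Notes on compound 2 and its epimer compound 3

The source may report more compounds than this note shows. Statements on the series, on what has been measured and on what is new or still open speak of the compounds shown alone.

compound 1 `CC1=CC[C@@]2(O)[C@H](C)CC[C@@H](C(C)C)[C@@H]2C1=O` — > 10 ug/mL
compound 2 `CC1=CC[C@]2(O)[C@@H]([C@@H]1O)[C@H](C(C)C)CC[C@H]2C` — > 10 ug/mL

Two compounds have been run in a functional assay on A549 cells (Homo sapiens) for cytotoxicity, read by MTT assay; a lower number here means a stronger inhibitor, a higher number a weaker inhibitor. Compound 1 gives only a limit there, > 10 ug/mL. Compound 2 also gives only a limit, > 10 ug/mL. Where compound 2 stands is therefore set by the limit of > 10 ug/mL in this assay, at which 2 of the 2 values shown sit; no number separates it from compound 1, and no ordering of the two can be drawn.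

Compound 3 `CC1=CC[C@]2(O)[C@@H]([C@H]1O)[C@H](C(C)C)CC[C@H]2C` has not been measured. Relative to compound 2 it differs as follows: the two compounds have the same atoms and bonds and differ only in configuration as drawn: 1 of 5 stereo elements differ; a stereocentre at a saturated ring carbon is drawn S in compound 2 and R in compound 3. Among the measured compounds shown here, no measured pair in this set differs in one place, so nothing measured tells how such a change moves the read-out. With compound 2 sitting at a limit, the expectation for compound 3 is a step that the limit leaves unreadable from compound 2 to compound 3 in this assay, that is, no move beyond the scatter in either direction. Compound 3 is accordingly estimated at 20 ug/mL, with a range from 7 ug/mL to 60 ug/mL, and the most likely outcome is expected to be another limit rather than a number.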

Compound 3, half-maximal inhibitory concentration: > 10 ug/mL
Compound 3: only a limit was reported (the forecaster's own chance of this, stated with the estimate: 80%); the middle value lies beyond the limit too.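

In this assay compound 3 gives > 10 ug/mL, which is a limit and not a number. Compound 2 also gives a limit, so no step can be read between compound 2 and compound 3: the limit of > 10 ug/mL in this assay, at which 3 of the 3 values shown sit.

From the compounds shown here alone, whether the configuration at that saturated ring carbon affects cytotoxicity at all, in either direction, remains open.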